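The compounds below may be only part of what the source reports. "The series", "measured", "known", "first", "only" and "open" are said of these compounds alone.

Among the measured compounds shown here, in a functional assay on HepG2 cells (Homo sapiens) for antiproliferative activity, read by XTT assay, with a stated time of 72 h (a higher number here means a weaker inhibitor, a lower number a stronger inhibitor), the three compounds measured so far give no number, only a limit. Compound 1 (`CSc1ncnc2c1c(-c1cccs1)cn2[C@@H]1O[C@H](CO)[C@@H](O)[C@H]1O`) reads > 20000 nM, which is a limit. Compound 2 (`CN(C)c1ncnc2c1c(-c1ccsc1)cn2[C@@H]1O[C@H](CO)[C@@H](O)[C@H]1O`) reads > 20000 nM, again a limit. Compound 3 (`Cc1nc(N)c2c(-c3ccoc3)cn([C@@H]3O[C@H](CO)[C@@H](O)[C@H]3O)c2n1`) reads > 20000 nM, also a limit. Compound 3 therefore has no rank of its own within this small set, and the picture so far is the limit of > 20000 nM in this assay, at which 3 of the 3 values shown sit.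

Compound 4 (`Cc1nc(N)c2c(I)cn([C@@H]3O[C@H](CO)[C@@H](O)[C@H]3O)c2n1`) differs from compound 3 at one place: iodo in place of furan-3-yl on an aromatic carbon. For the measured compounds named here, no measured pair here shows what such a swap does, so the expectation rests on little. The limit of compound 3, > 20000 nM, leaves room for a real number only on the stronger side, so a modest step in that direction is expected in this assay, and a reading at the same limit remains quite possible. The estimated change is an at least 2.0-fold lower number from compound 3 to compound 4 (0.30 log units; that floor lies within the scatter). For compound 4 the expected half-maximal inhibitory concentration is 10000 nM, with an estimated range from 2000 nM to 20000 nM.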

Compound 4, half-maximal inhibitory concentration: 6310 nM
For compound 4 the middle estimate is 1.6-fold (0.20 log units) above the measured one; the range from low to high includes it.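

Among the compounds shown here, on the aromatic carbon two ring bonds from the ring nitrogen, swapping furan-3-yl for iodo yields the first real number in this set: in this assay the change is an at least 3.1-fold lower number from compound 3 to compound 4 (0.50 log units; beyond the scatter). For the compounds shown here, this position therefore responds to the group it carries, and the single iodine atom of compound 4 goes with measurable antiproliferative activity, which the furan-3-yl ring of compound 3 does not reach within the range tested. The full size of the step stays unknown because compound 3 gives only a limit: the limit of > 20000 nM in this assay, at which 3 of the 4 values shown sit.

From the compounds shown here alone, whether the change comes from iodine itself or from the loss of the furan-3-yl ring remains open. A bromine atom, a methyl group or an amine on this same carbon would help separate those two readings.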